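Carbamate side chain and half-life in liver fraction

A few compounds are considered here, and "the series" means these few. Any claim that something is new, unique, unknown or untested is made for them only; others in the source may bear on it.

The measured compounds are:
- compound 1, `O=C(NC1CCCCC1)Oc1cccc(-c2ccccc2)c1`: 0.1 h
- compound 2, `O=C(NCCCCc1ccccc1)Oc1cccc(-c2ccccc2)c1`: 0.322 h
- compound 3, `O=C(NC1CCC1)Oc1cccc(-c2ccccc2)c1`: 0.0417 h

In an in vitro ADME assay on S9 fraction from liver (Rattus norvegicus, strain Wistar) for metabolic stability, read by HPLC, tested at 1 uM (a higher number here means that the compound lasts longer, a lower number that the compound disappears faster), compound 1 stands second highest of the three numbers. Among the measured compounds shown here, its nearest neighbour is compound 3, and that pair is the one measured step that changes a single place: a 2.4-fold lower number from compound 1 to compound 3 (0.38 log units; beyond the scatter). Compound 2 lies furthest from compound 1, and compound 2 gives 0.322 h against compound 1 with 0.1 h, though these two differ in more than one place, so only their two values can be compared.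

Compound 4, `CCCCNC(=O)Oc1cccc(-c2ccccc2)c1`, has not yet been measured in this assay. It differs from compound 1 in one place: butyl in place of cyclohexyl on an amide-type nitrogen

The step from compound 1 to compound 3 bears on this change, since both replace the cyclohexyl on the amide-type nitrogen with a smaller group; that step was modest and went downward. Compound 2, carrying an open chain on the same nitrogen, shows a higher number, but its chain is not butyl. The two hints pull in opposite directions, so no step beyond the scatter is expected, with a wide range.

For compound 4 the estimated value is 0.09 h, from 0.035 h to 0.25 h. This estimate means a step of a 1.1-fold lower number from compound 1 to compound 4 (0.05 log units; within the scatter) and is expected to stay within the scatter.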

Compound 4, half-life in the liver assay: 0.03 h
Beside the measured number, compound 4's estimate is 3.0-fold (0.48 log units) above it; the measured number lies below the stated range.
By their numbers in the liver assay, from the lowest: compounds 4 and 3 (each within the scatter of the next); then compound 1; then compound 2.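

In the liver assay, the open chain does not carry the higher number of compound 2 with it: butyl gives a 3.3-fold lower number from compound 1 to compound 4 (0.52 log units; beyond the scatter), so on this nitrogen an open chain alone does not lift the value over cyclohexyl. Ring and no ring read alike at the small end, with a 1.4-fold lower number from compound 3 to compound 4 (0.14 log units; within the scatter), while the largest step among these compounds comes with the loss of the phenyl, an 11-fold lower number from compound 2 to compound 4 (1.03 log units; beyond the scatter), which places the high value of compound 2 with that phenyl and not with the chain. In a physicochemical assay for pharmacokinetics, read by HPLC, at pH 9.0 (on this read-out lower numbers stand for a shorter-lived compound and higher numbers for a longer-lived compound), compound 1 gives 0.678 h and compound 4 gives 0.715 h, a pair within the scatter, so the change that moves the number in the liver assay leaves this read-out where it was.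

No supporting measurement speaks to the reason for these differences. From the compounds shown here alone, how a longer chain without the phenyl, or an amine or a carboxylic acid in place of the phenyl of compound 2, would read in the liver assay stays open.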